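Working notes on cytotoxicity in a small series

A few compounds are considered here, and "the series" means these few. Any claim that something is new, unique, unknown or untested is made for them only; others in the source may bear on it.

Measured so far:
- compound 1 `COc1ccc(-c2nc3cc(C(F)(F)F)ccc3[nH]2)c(N)c1`: 4000 nM
- compound 2 `CC(=O)Nc1ccc(-c2nc3cc(C(F)(F)F)ccc3n2C2CCCCC2)cc1`: 17000 nM
- compound 3 `COc1ccc(-c2nc3cc(C(C)=O)ccc3[nH]2)c(OC)c1OC`: > 100000 nM

All three were run in an ADME assay on MDBK cells (Bos taurus) for cytotoxicity, read by MTT assay, with a stated time of 96 h; on this read-out lower numbers stand for higher toxicity in this test and higher numbers for lower toxicity in this test. Compound 1 gives 4000 nM and stands at the lower of the two numbers measured, with compound 2 at 17000 nM, a gap that lies beyond the scatter. For compound 3 the assay returns only a limit, > 100000 nM, and this is the limit of > 100000 nM in this assay, at which 1 of the 3 values shown sits; no number is known for it. Among the compounds with values here, no two measured compounds differ in a single place, so no measured step can be drawn between them.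

The unmeasured compound 4 `COc1ccc(-c2nc3cc(C(F)(F)F)ccc3[nH]2)c(OC)c1` is reached from compound 1 by one change: methoxy in place of amino on an aromatic carbon. The two differ nowhere else. Within the data shown here, with no measured step of the same kind available, the size of the effect on this assay cannot be read from the data. The working expectation is a modest move toward a higher number, that is lower toxicity, though a result within the scatter of compound 1 would not be surprising; the step from compound 1 to compound 4 is expected to be a 2.0-fold higher number from compound 1 to compound 4 (0.30 log units; within the scatter). Compound 4 is therefore estimated at 8000 nM, with a range from 2500 nM to 30000 nM.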

Compound 4, half-maximal cytotoxic concentration: > 100000 nM
Compound 4 gave a limit, no number; the forecaster's own chance of this, stated with the estimate: 10%; at least 12-fold (1.09 log units) between middle value and limit.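

The position ortho to a large group carries much of the read-out of compound 1: with methoxy in place of amino on this aromatic carbon, this assay shows an at least 25-fold higher number from compound 1 to compound 4 (1.39 log units; beyond the scatter). Within the data shown here, the earlier compounds gave no step at all, so this pair is the first evidence that a single substituent on the shared core can move this read-out well beyond the scatter. The value for compound 4 is a limit of the assay and not a number, so the step gives only a lower bound on the size of the change: the limit of > 100000 nM in this assay, at which 2 of the 4 values shown sit.

The compounds shown leave open whether the result depends on the amino group of compound 1 or on the methoxy group of compound 4, a question that a hydroxyl group, a methyl group, a dimethylamino group or plain hydrogen at the same carbon would help to separate. Going by these compounds, this reading also rests on one pair, so it remains open whether the same change gives a similar step on a different core or with a different group in place of the trifluoromethyl.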